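Methoxy Added to the Phenol Ester of Compound 2

A few compounds are considered here, and "the series" means these few. Any claim that something is new, unique, unknown or untested is made for them only; others in the source may bear on it.

Measured compounds:
Compound 1 `C=CC(=C)CC[C@@H]1[C@@]2(C)CCC[C@](C)(COC(=O)/C=C\c3ccc(O)cc3)[C@@H]2CC[C@@]1(C)O` gives 15100 nM in a functional assay on MCF7 cells (Homo sapiens) for cytotoxicity, read by MTT assay, with a stated time of 48 h; on this read-out higher numbers stand for weaker inhibition and lower numbers for stronger inhibition.
Compound 2 `C=CC(=C)CC[C@@H]1[C@@]2(C)CCC[C@](C)(COC(=O)/C=C/c3ccc(O)cc3)[C@@H]2CC[C@@]1(C)O` gives 16600 nM.
Compound 3 `C=CC(=C)[C@@H](O)C[C@H]1C(=C)CC[C@@H]2[C@]1(C)CCC[C@]2(C)C(=O)O` gives > 40000 nM, which is a limit of the assay and not a number.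

For the measured compounds named here, compound 2 has the highest of the two numbers, yet the only measured step, a 1.1-fold higher number from compound 1 to compound 2 (0.04 log units; within the scatter), stays within the scatter and concerns only the drawn configuration of a double bond. Compound 4 `C=CC(=C)CC[C@@H]1[C@@]2(C)CCC[C@](C)(COC(=O)/C=C/c3ccc(O)c(OC)c3)[C@@H]2CC[C@@]1(C)O` differs from compound 2 by methoxy in place of hydrogen on an aromatic carbon. Going by the values given here, no measured step touches a change of this kind, so nothing here points to a shift beyond the scatter in this assay. Compound 4 is therefore expected to give 16000 nM, with a range from 8000 nM to 32000 nM. That estimate means a 1.0-fold lower number from compound 2 to compound 4 (0.02 log units; within the scatter), expected to fall within the scatter.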

Compound 4, half-maximal inhibitory concentration: 13500 nM
For compound 4 the middle estimate is 1.2-fold (0.07 log units) above the measured one; measured number inside the range.
By their numbers in this assay, from the lowest: compounds 4, 1 and 2 (each within the scatter of the next). At a limit, above all of these: compound 3.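

Methoxy in place of hydrogen on this aromatic carbon, ortho to a hydroxy group, is a change no earlier step touched, and in this assay it gives a 1.2-fold lower number from compound 2 to compound 4 (0.09 log units; within the scatter). The comparison that also switches the drawn double bond gives a 1.1-fold lower number from compound 1 to compound 4 (0.05 log units; within the scatter), and the link between those two starting compounds is simple: the fact that compounds 1 and 2 differ only in the configuration as drawn So this position takes a methoxy with no shift beyond the scatter.

Still open, as far as these compounds go, is whether an amine or a carboxylic acid on this same carbon would move the number beyond the scatter.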